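From 5-methylthiophen-2-yl to 2,4-dimethyl-1,3-thiazol-5-yl

The source may report more compounds than this note shows. Statements on the series, on what has been measured and on what is new or still open speak of the compounds shown alone.

In a toxicity assay on MT2 cells (Homo sapiens) for cytotoxicity, read by XTT assay, with a stated time of 4 days (on this read-out lower numbers stand for higher toxicity in this test and higher numbers for lower toxicity in this test), compound 1 `COc1cccc(CCOc2ccc(-c3c(C)nc(C)c([C@H](OC(C)(C)C)C(=O)O)c3N3CCC(C)(C)CC3)cc2)c1` gives >= 33500 nM, which is a limit rather than a number. Compound 2 `Cc1ccc(CCOc2ccc(-c3c(C)nc(C)c([C@H](OC(C)(C)C)C(=O)O)c3N3CCC(C)(C)CC3)cc2)s1` gives >= 25000 nM, also a limit, so it has no exact position. Within the data shown here, the only measured step bearing on the change, a step that the two limits leave unreadable from compound 1 to compound 2, therefore has no readable size. Compound 3 `Cc1nc(C)c(CCOc2ccc(-c3c(C)nc(C)c([C@H](OC(C)(C)C)C(=O)O)c3N3CCC(C)(C)CC3)cc2)s1` carries 2,4-dimethyl-1,3-thiazol-5-yl in place of 5-methylthiophen-2-yl on a saturated chain carbon, two bonds along the chain from an oxygen on an aromatic ring. The expected step that the limit leaves unreadable from compound 2 to compound 3 stays within the scatter, with no direction foreseen. For compound 3 the estimate is 30000 nM, with an expected range of 15000 nM to 60000 nM.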

Compound 3, half-maximal cytotoxic concentration: >= 25000 nM
Compound 3 ended at the assay's limit; the forecaster's own chance of this, stated with the estimate: 75%; the middle value is on the limit's open side.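

In this assay, among these compounds, compound 1, compound 2 and compound 3 all end at limits, so no step among them can be read. From the compounds shown here alone, whether exchanging the group on the chain shifts the half-maximal cytotoxic concentration at all stays open.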